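This account rests on a few compounds, and the source may have more. Where it says the series, first, only, none or still open, it means among the compounds named here.

Measured compounds:
Compound 1 `COc1ccc(F)cc1CNCCCNc1ccnc2cc(Cc3ccc(F)cc3Cl)ccc12` gives 9.47 in a physicochemical assay for acid dissociation.
Compound 2 `COc1ccc(F)cc1CNCCCNc1ccnc2cc(CC3CCCCC3)ccc12` gives 9.47 in this assay.
Compound 3 `COc1cccc(CNCCCNc2ccnc3cc(CC4CCCCC4)ccc23)c1O` gives 9.47 in this assay.

All three share one core; compound 3 differs from compound 2 by 2-hydroxy-3-methoxyphenyl in place of 5-fluoro-2-methoxyphenyl on a saturated chain carbon bound to an amine nitrogen, and this change made no change at the digits printed from compound 2 to compound 3 (within the scatter). Compound 4 `COc1cccc(CNCCCNc2ccnc3cc(Cc4ccc(F)cc4Cl)ccc23)c1O` has not been measured yet. It differs from compound 3 by 2-chloro-4-fluorophenyl in place of cyclohexyl on a saturated chain carbon bound to an aromatic carbon. Among the measured compounds shown here, that is the same change as the one from compound 2 to compound 1, (2-chloro-4-fluorophenyl in place of cyclohexyl on a saturated chain carbon bound to an aromatic carbon), made on the same place, and there it made no change at the digits printed from compound 2 to compound 1 (within the scatter). Because the earlier step of no change at the digits printed from compound 2 to compound 1 (within the scatter) stayed within the scatter, and because compound 3 sits at 9.47, compound 4 is expected to show a step of about no change at the digits printed from compound 3 to compound 4 (within the scatter) in this assay. Compound 4 is therefore estimated at 9.47, most likely between 9.2 and 9.75.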

Compound 4, acid dissociation constant: 9.47
Compound 4: middle estimate and measured number agree at the digits printed; measured number inside the range.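

In this assay, 2-chloro-4-fluorophenyl in place of cyclohexyl gave no change at the digits printed from compound 3 to compound 4 (within the scatter), matching the earlier step of no change at the digits printed from compound 2 to compound 1 (within the scatter), so on these two cores the change carried over without altering the read-out, and the other change, 2-hydroxy-3-methoxyphenyl in place of 5-fluoro-2-methoxyphenyl, likewise gave no change at the digits printed from compound 1 to compound 4 (within the scatter). Among the compounds shown here, this shows only that a step too small to read stayed too small to read on a second core; it does not show that a step of clear size would carry over, or that the same would hold on other cores. Nothing available explains why these numbers stay level.

On these data alone, whether a carboxylic acid or an amine at this place would leave the read-out level remains open. A longer chain in place of the one carrying the amine nitrogen is also an open case.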